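A Propargylic Ester Replaces the Amide of Compound 3

The source may hold more compounds than are shown below. What is called first, only, known or untested is meant among the compounds shown, and "the series" means these compounds.

Compound 3 `CCn1c(C(=O)NCCCN(C)C)ccc1C(CC)(CC)c1ccc(OCC(O)C(C)(C)C)c(C)c1` shows the lowest number of the three compounds in an assay on HL-60 cells for agonist activity at vitamin D3 receptor (Homo sapiens), read by microscopy, with a stated time of 96 h (a higher number here means that more compound is needed for the effect, a lower number that less compound is needed), at 37 nM. Compound 1 `CCn1c(C(=O)NCCN(C)C)ccc1C(CC)(CC)c1ccc(OCC(=O)C(C)(C)C)c(C)c1` gives 77 nM, and compound 2 `CCn1c(C(=O)NCCCN(C)C)ccc1C(CC)(CC)c1ccc(OCC(=O)C(C)(C)C)c(C)c1` gives 96 nM. Compound 4 `C#CC(C)OC(=O)c1ccc(C(CC)(CC)c2ccc(OCC(O)C(C)(C)C)c(C)c2)n1CC` differs from compound 3 in a single place: (1-methylprop-2-yn-1-yl)oxy in place of (3-(dimethylamino)propyl)amino on a carbonyl carbon. Neither measured step touches this carbonyl carbon. The change a 1.2-fold higher number from compound 1 to compound 2 (0.10 log units; within the scatter) stayed within the scatter, while a 2.6-fold lower number from compound 2 to compound 3 (0.41 log units; beyond the scatter) was modest; both concern other parts of the shared core, so they offer little guidance on an exchange at the carbonyl carbon. The step expected here is a 1.6-fold higher number from compound 3 to compound 4 (0.21 log units; within the scatter), with wide uncertainty. Compound 4 is therefore estimated at 60 nM, with a plausible range from 15 nM to 250 nM.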

Compound 4, half-maximal effective concentration: 200 nM
Compound 4: middle estimate off by 3.3-fold (0.52 log units), on the low side, and the stated range covers the measured number.
By their numbers in this assay, from the lowest: compound 3; then compounds 1 and 2 (each within the scatter of the next); then compound 4.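

The carbonyl carbon is not a silent position: putting (1-methylprop-2-yn-1-yl)oxy in place of (3-(dimethylamino)propyl)amino gives a 5.4-fold higher number from compound 3 to compound 4 (0.73 log units; beyond the scatter), the largest step among these compounds. The exchange removes both nitrogens of the leaving group and its hydrogen-bond donor, but the data cannot show which of these changes matters. Nothing measured here explains the step.

Still open, from the compounds shown here alone, is whether the higher number follows the dimethylamino group, the amide hydrogen or the triple bond. A plain propylamino group or a methyl ester on this carbonyl carbon would help separate these.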